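The source may report more compounds than this note shows. Statements on the series, on what has been measured and on what is new or still open speak of the compounds shown alone.

Measured so far in an ADME assay on microsomes from liver (Homo sapiens) for metabolic stability, read by HPLC, using NADPH, with stated times of 5 min and 60 min, tested at 10 uM; on this read-out higher numbers stand for fast clearance and lower numbers for slow clearance:
- compound 1 `CCS(=O)(=O)Nc1ccc(Oc2ccc(C#N)cc2)c(-c2cn(C)c(=O)c3[nH]ccc23)c1`: 41.7 mL/min/kg
- compound 2 `CCS(=O)(=O)Nc1ccc(Oc2ccc(C(F)(F)F)cc2)c(-c2cn(C)c(=O)c3[nH]ccc23)c1`: 128 mL/min/kg
- compound 3 `CCS(=O)(=O)Nc1ccc(OCC(C)(C)C)c(-c2cn(C)c(=O)c3[nH]ccc23)c1`: 283 mL/min/kg

Of these three, compound 3 has the highest number, at 283 mL/min/kg, and so the fastest clearance. Compound 4 `CCS(=O)(=O)Nc1ccc(OC2CCN(C)CC2)c(-c2cn(C)c(=O)c3[nH]ccc23)c1` keeps the shared core but has 1-methylpiperidin-4-yl in place of neopentyl on an oxygen on an aromatic ring.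

Among the compounds with values here, no measured pair makes exactly this swap, and no measured compound carries a ring nitrogen, so the evidence is indirect. The closest guides are the other swaps on the same oxygen. In this assay there is a 6.8-fold higher number from compound 1 to compound 3 (0.83 log units; beyond the scatter), and there is also a 2.2-fold higher number from compound 2 to compound 3 (0.34 log units; beyond the scatter). Both are rises on arriving at neopentyl, so leaving it seems more likely to bring the number down than to raise it, though the new group is unlike the two aromatic ones.

A drop of similar size is therefore expected, and the estimated change is a 2.6-fold lower number from compound 3 to compound 4 (0.41 log units; beyond the scatter). In this assay, compound 4 is expected at 110 mL/min/kg, with an estimated range of 40 mL/min/kg to 300 mL/min/kg.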

Compound 4, clearance: < 28.4 mL/min/kg
Compound 4 gave a limit, no number; the forecaster's own chance of this, stated with the estimate: 5%; at least 3.8-fold (0.58 log units) between middle value and limit.
By their numbers in this assay, from the lowest: compound 1; then compound 2; then compound 3. At a limit, below all of these: compound 4.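

In this assay, compound 4 gives a limit rather than a number: the limit of < 28.4 mL/min/kg in this assay, at which 1 of the 4 values shown sits. Within the data shown here, until now, the only swaps on this oxygen led to neopentyl and raised the number, whereas 1-methylpiperidin-4-yl, the one group here with a ring and a nitrogen, brings it down clearly: an at least 9.9-fold lower number from compound 3 to compound 4 (0.99 log units; beyond the scatter), and an at least 4.5-fold lower number from compound 2 to compound 4 (0.65 log units; beyond the scatter). The remaining step is an at least 1.4-fold lower number from compound 1 to compound 4 (0.16 log units; that floor lies within the scatter), and with its floor inside the scatter, it does not establish an order between the 4-cyanophenyl and 1-methylpiperidin-4-yl compounds.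

From the compounds shown here alone, how far the number falls stays open, as does whether the ring or its nitrogen matters more. A cyclohexyl group on the same oxygen would separate those two, and a piperidin-4-yl group without the methyl would show what the methyl contributes.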